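Swapping the aryl amide group: compound 2 to compound 3

This account rests on a few compounds, and the source may have more. Where it says the series, first, only, none or still open, it means among the compounds named here.

Measured compounds:
compound 1: `COc1ccc(NC(=O)c2nnc(COc3ccc(CCC(=O)O)cc3)s2)cc1`, > 10000 nM
compound 2: `Cc1ccccc1NC(=O)c1nnc(COc2ccc(CCC(=O)O)cc2)s1`, 1520 nM

Compound 1 carries a 4-methoxyphenyl group on the amide-type nitrogen. In a functional assay on CHO cells for agonist activity at Free fatty acid receptor 1 (Homo sapiens), read by calcium flux (on this read-out higher numbers stand for an effect only at larger amounts of compound and lower numbers for an effect already at smaller amounts), compound 1 gives > 10000 nM, which is a limit of the assay rather than a number. Among the compounds with values here, compound 2 bears a 2-methylphenyl group in the same place and is the only compound with a number; in this assay compound 2 gives 1520 nM. Within the data shown here, the change an at least 6.5-fold lower number from compound 1 to compound 2 (0.81 log units; beyond the scatter) marks the one measured step, with the starting point sitting at the limit of > 10000 nM in this assay, at which 1 of the 2 values shown sits.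

Compound 3, `O=C(O)CCc1ccc(OCc2nnc(C(=O)Nc3ccc(Cl)cc3)s2)cc1`, differs from compound 2 by 4-chlorophenyl in place of 2-methylphenyl on an amide-type nitrogen. The measured step bears on it only loosely, since a ring substituent moves away from the position found in compound 2 toward a pattern resembling compound 1. The expected step of a 2.3-fold higher number from compound 2 to compound 3 (0.36 log units; beyond the scatter) therefore points to a weaker effect. The estimate for compound 3 is 3500 nM, within 900 nM to 15000 nM.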

Compound 3, half-maximal effective concentration: 3690 nM
Beside the measured number, compound 3's estimate is 1.1-fold (0.02 log units) below it, and the stated range covers the measured number.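

Compound 3 shows that a ring group carried as a 4-substituent on the amide-type nitrogen can still give a measurable number in this assay: chloro in place of methoxy on an aromatic carbon gives an at least 2.7-fold lower number from compound 1 to compound 3 (0.43 log units; beyond the scatter). Compound 1 gives a limit of the assay and not a number, so this step is only a minimum: the limit of > 10000 nM in this assay, at which 1 of the 3 values shown sits. Against the 2-methylphenyl group, the 4-chlorophenyl group gives a 2.4-fold higher number from compound 2 to compound 3 (0.39 log units; beyond the scatter), which leaves compound 2 with the lowest number of the three.

Between compound 2 and compound 3, both the substituent and its place on the ring change, so the two effects cannot be separated. A 4-methylphenyl or 2-chlorophenyl group on the same nitrogen would tell them apart.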